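A few compounds are considered here, and "the series" means these few. Any claim that something is new, unique, unknown or untested is made for them only; others in the source may bear on it.

Measured compounds:
compound 1, `NC[C@@H]1CCCc2cc(S(=O)(=O)c3cccc(F)c3)ccc21`; in an assay on isolated protein for displacement of a labelled ligand from 5-hydroxytryptamine receptor 6 (Homo sapiens) (on this read-out lower numbers stand for stronger inhibition and higher numbers for weaker inhibition), compound 1 gives 0.0794 nM
compound 2, `O=C(NC[C@@H]1CCCc2cc(S(=O)(=O)c3cccc(F)c3)ccc21)c1ncc[nH]1`; in this assay compound 2 gives 15.9 nM

For the measured compounds named here, compound 2 stands at the higher of the two numbers, with compound 1 as its only neighbour; that single step is a 200-fold higher number from compound 1 to compound 2 (2.30 log units; beyond the scatter), which is large and well beyond the scatter. Compound 3, `O=C(NC[C@@H]1CCCc2cc(S(=O)(=O)c3cccc(F)c3)ccc21)[C@H]1CCCN1`, has not yet been measured. It differs from compound 2 in one place: pyrrolidin-2-yl in place of 1H-imidazol-2-yl on a carbonyl carbon. Going by the values given here, no measured step covers this exchange of one five-membered ring for another on the carbonyl carbon. Among the compounds with values here, the one step in hand concerns the carbonyl on the amine nitrogen, and compound 3 keeps that carbonyl, so its nearest anchor is compound 2 rather than compound 1. The entering pyrrolidin-2-yl ring, like the leaving imidazol-2-yl ring, carries one hydrogen-bond donor and one hydrogen-bond acceptor, so the data give no clear direction. Compound 3 is therefore expected to stay close to compound 2, with a step of a 2.0-fold lower number from compound 2 to compound 3 (0.30 log units; within the scatter) that need not exceed the scatter. Compound 3 is estimated at 8 nM, in a range from 1.5 nM to 40 nM.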

Compound 3, inhibition constant: 0.631 nM
For compound 3 the middle estimate is 13-fold (1.10 log units) above the measured one, and the stated range ends above it.
By their numbers in this assay, from the lowest: compound 1; then compound 3; then compound 2.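

The exchange on the carbonyl carbon shows that this position responds strongly to the identity of the ring: in this assay, pyrrolidin-2-yl in place of 1H-imidazol-2-yl gives a 25-fold lower number from compound 2 to compound 3 (1.40 log units; beyond the scatter), even though the two groups match in heavy-atom count, hydrogen-bond donors and hydrogen-bond acceptors, so these counts do not predict the read-out here. The earlier compounds shown here suggested a large cost for placing an acyl group on the amine nitrogen, but that cost depends on what the carbonyl carries, since the (pyrrolidin-2-yl)carbonyl group gives only a 7.9-fold higher number from compound 1 to compound 3 (0.90 log units; beyond the scatter), which is modest yet still beyond the scatter. Nothing available explains the difference between the two rings.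

Going by these compounds, it remains open how a cyclopentyl ring, which has no ring nitrogen, or a piperidin-2-yl ring would read on the same carbonyl carbon, and how the opposite stereoisomer of the pyrrolidin-2-yl group would compare. On these data alone, it is also open whether any group on this carbonyl can bring an acylated compound level with compound 1 at 0.0794 nM.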